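The source may hold more compounds than are shown below. What is called first, only, known or untested is meant among the compounds shown, and "the series" means these compounds.

In a functional assay on MIA PaCa-2 cells (Homo sapiens) for cytotoxicity, read by WST assay, with a stated time of 48 h (a higher number here means a weaker inhibitor, a lower number a stronger inhibitor), compound 3 (`N#C/C(=C\c1c[nH]c2ccccc12)C(=O)c1c[nH]c2ccccc12`) gives 36800 nM. This puts it within the scatter of compound 1 (`COc1ccc2[nH]cc(/C=C(\C#N)C(=O)c3c[nH]c4ccccc34)c2c1`), which gives 25100 nM. Compound 2 (`N#C/C(=C\c1cn(Cc2ccc(Cl)cc2)c2ccccc12)C(=O)c1c[nH]c2cc(F)ccc12`) gives 16600 nM, a lower number than that of compound 3 and beyond the scatter.

Compound 4 (`N#C/C(=C\c1cn(Cc2ccc(Cl)cc2)c2ccccc12)C(=O)c1c[nH]c2ccccc12`) is reached from compound 3 by placing 4-chlorobenzyl in place of hydrogen on an aromatic nitrogen.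

Going by the values given here, the only measured single-site step is a 1.5-fold higher number from compound 1 to compound 3 (0.17 log units; within the scatter). It involves methoxy and hydrogen on an aromatic carbon, not the aromatic nitrogen, so it says little about this change beyond showing that the series can stay flat under a substitution. The closest evidence is compound 2, which gives 16600 nM and already carries the 4-chlorobenzyl group, but it also has a fluorine that compound 4 lacks. Among the compounds with values here, no measured pair isolates the benzyl change, so the inference is indirect.

A modest move towards a lower number is therefore expected, close to the level of compound 2. The expected step is a 1.9-fold lower number from compound 3 to compound 4 (0.29 log units; within the scatter). For compound 4 the estimated value is 19000 nM, with an expected range of 8000 nM to 40000 nM.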

Compound 4, half-maximal inhibitory concentration: > 50000 nM
Compound 4 ended at the assay's limit; the forecaster's own chance of this, stated with the estimate: 5%; middle value at least 2.6-fold (0.42 log units) away from the limit.
By their numbers in this assay, from the lowest: compounds 2, 1 and 3 (each within the scatter of the next, the first and the last beyond it). At a limit, above all of these: compound 4.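

In this assay compound 4 gives > 50000 nM, which is a limit of the assay and not a number: the limit of > 50000 nM in this assay, at which 1 of the 4 values shown sits.

Placing 4-chlorobenzyl on the aromatic nitrogen gives an at least 1.3-fold higher number from compound 3 to compound 4 (0.13 log units; that floor lies within the scatter), so this change brings no move towards a lower number, although the floor of the step alone does not establish a real rise. Going by these compounds alone, with 4-chlorobenzyl held in place, hydrogen in place of fluoro on an aromatic carbon gives an at least 3.0-fold higher number from compound 2 to compound 4 (0.47 log units; beyond the scatter), the first single-site step in this set that is beyond the scatter, and so the lower number of compound 2 cannot be credited to the 4-chlorobenzyl group alone.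

The compounds shown leave open how far compound 4 lies past its limit, and whether fluoro on the same aromatic carbon would shift the number when the aromatic nitrogen carries hydrogen, as in compound 3. They also leave open how a small methyl group, or a longer chain ending in an amine or a carboxylic acid, would read on that nitrogen in this assay.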